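Swapping the Amine Substituent: Compound 3 to Compound 4

The source may report more compounds than this note shows. Statements on the series, on what has been measured and on what is new or still open speak of the compounds shown alone.

Of the compounds shown here, three sharing one core have been tested in a functional assay on PC-3 cells (Homo sapiens) for cytotoxicity, read by MTT assay; a lower number here means a stronger inhibitor, a higher number a weaker inhibitor. Compound 1 `COc1cc(/C=C/C(=O)c2sc(Nc3ccccc3C)nc2C)cc(OC)c1OC` returns only the limit > 25000 nM, so no number is known for it. Compound 2 `Cc1ccc(Nc2nc(C)c(C(=O)/C=C/c3ccc(Cl)cc3)s2)cc1` likewise gives only the limit > 25000 nM. Compound 3 `Cc1ccc(Nc2nc(C)c(C(=O)/C=C/c3ccccc3)s2)cc1`, the starting point of this step, also sits at the limit > 25000 nM, so its standing can be given only as that limit. Within the data shown here, the single step between measured compounds that differ in one place, a step that the two limits leave unreadable from compound 2 to compound 3, has both of its ends at a limit and so its size is not readable. All the measured values show together is the limit of > 25000 nM in this assay, at which 3 of the 3 values shown sit.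

Compound 4 `Cc1nc(Nc2cccc(Cl)c2)sc1C(=O)/C=C/c1ccccc1` differs from compound 3 in one place: 3-chlorophenyl in place of 4-methylphenyl on a nitrogen on an aromatic ring. Among the measured compounds shown here, no measured step concerns a change of this kind, and the one measured step that exists, an exchange of chloro for hydrogen elsewhere in the molecule, cannot be read. Nothing in the data therefore points to a gain in potency large enough to bring compound 4 under the limit, and nothing points against it. The expected step that the limit leaves unreadable from compound 3 to compound 4 is thus estimated as none beyond the scatter. Compound 4 is expected to give 35000 nM, within 8000 nM to 150000 nM, and most likely to be reported again only as a limit.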

Compound 4, half-maximal inhibitory concentration: > 25000 nM
Compound 4: only a limit was reported; the forecaster's own chance of this, stated with the estimate: 85%; the middle value is on the limit's open side.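

In this assay compound 4 gives > 25000 nM as a limit, not a number. Among these compounds, compound 3 also stands at a limit, so the step between compound 3 and compound 4 cannot be read and no new step emerges. The compounds shown leave open how potent any of them is and whether any single change alters potency: the limit of > 25000 nM in this assay, at which 4 of the 4 values shown sit.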